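A few compounds are considered here, and "the series" means these few. Any claim that something is new, unique, unknown or untested is made for them only; others in the source may bear on it.

Measured in a functional assay on KETR3 cells (Homo sapiens) for inhibition, read by MTT assay, with a stated time of 120 h; a higher number here means a weaker inhibitor, a lower number a stronger inhibitor:
Compound 1 `CNC(=O)/C(C)=C/c1ccc(NC(=O)Nc2ccc(Cl)c(C(F)(F)F)c2)cc1`: > 50000 nM
Compound 2 `CNC(=O)CCc1ccc(NC(=O)Nc2ccc(Cl)c(C(F)(F)F)c2)cc1`: 24000 nM

The entry for compound 1 is a limit of this assay, not a number. For the measured compounds named here, compound 2, at 24000 nM, holds the only true number so far. Compound 3 `CNC(=O)C#Cc1ccc(NC(=O)Nc2ccc(Cl)c(C(F)(F)F)c2)cc1` carries 2-(methylcarbamoyl)ethynyl in place of 2-(methylcarbamoyl)ethyl on an aromatic carbon. Going by the values given here, the one measured step that bears on this is an at least 2.0-fold lower number from compound 1 to compound 2 (0.31 log units; beyond the scatter), in which 2-(methylcarbamoyl)ethyl replaced 2-(methylcarbamoyl)prop-1-en-1-yl. With 2-(methylcarbamoyl)ethyl leaving here, the expected step is a 1.7-fold higher number from compound 2 to compound 3 (0.22 log units; within the scatter), small, towards a higher number and probably within the scatter. For compound 3 the estimate is 40000 nM, with an expected range from 15000 nM to 90000 nM.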

Compound 3, half-maximal inhibitory concentration: 24700 nM
The estimate for compound 3 lay 1.6-fold (0.21 log units) above the measured number, and the stated range covers the measured number.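

In this assay, the 2-(methylcarbamoyl)ethynyl and 2-(methylcarbamoyl)ethyl chains cannot be told apart at this position, para to a large group: the exchange gives a 1.0-fold higher number from compound 2 to compound 3 (0.01 log units; within the scatter). Exchanging 2-(methylcarbamoyl)prop-1-en-1-yl for 2-(methylcarbamoyl)ethynyl gives an at least 2.0-fold lower number from compound 1 to compound 3 (0.30 log units; that floor lies within the scatter), a step that rests on a limit and not on a number: the limit of > 50000 nM in this assay, at which 1 of the 3 values shown sits.

Going by these compounds, whether an amine, a carboxylic acid or a longer chain at this position would shift the number beyond the scatter stays open. So does whether any group here would bring this assay to a clearly lower number.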